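Aryl-urea series: ethyl to tert-butyl on the aniline ring

The source may hold more compounds than are shown below. What is called first, only, known or untested is meant among the compounds shown, and "the series" means these compounds.

Measured compounds:
compound 1 `COc1cc(NC(=O)Nc2cc(Nc3ccc(OC)c(C)c3)ncn2)cc(OC)c1`, 62%
compound 2 `CCc1cccc(Nc2cc(NC(=O)Nc3cc(OC)cc(OC)c3)ncn2)c1`, 82.1%
compound 3 `COc1ccc(C(F)(F)F)cc1Nc1cc(NC(=O)Nc2c(Cl)cccc2Cl)ncn1`, 89%

Among the compounds with values here, in a functional assay on PC-9 cells (Homo sapiens) for inhibition, read by MTT assay, with a stated time of 48 h, tested at 10 uM (on this read-out higher numbers stand for more inhibition at the one concentration tested (going by the name of the read-out) and lower numbers for less inhibition), compound 2 stands second highest of the three numbers; compound 3 lies within the scatter of it, and compound 1 lies below it beyond the scatter, the one measured step being a number 20.1 percentage points higher from compound 1 to compound 2 (beyond the scatter). Compound 4 `COc1cc(NC(=O)Nc2cc(Nc3cccc(C(C)(C)C)c3)ncn2)cc(OC)c1` is not yet measured in this assay. It differs from compound 2 in one place: tert-butyl in place of ethyl on an aromatic carbon. Within the data shown here, no measured step exchanges one alkyl chain for another on this ring; the single step recorded, from compound 1 to compound 2, swaps a substituted phenyl for a 3-ethylphenyl, and so does not bear directly on a change of ethyl to tert-butyl. Compounds 2 and 3 show that varied groups on this ring give values within the scatter of each other. Because compound 2 gives 82.1%, compound 4 is expected to stay near it, with a step of a number 2.1 percentage points lower from compound 2 to compound 4 (within the scatter), not beyond the scatter. The estimate for compound 4 is 80%, range 62% to 93%.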

Compound 4, a percentage reported as inhibition, at one concentration (the size of the read-out at that concentration, not a potency): 68%
For compound 4 the middle estimate is 12 percentage points above the measured one; measured number inside the range.
By their numbers in this assay, from the lowest: compounds 1 and 4 (each within the scatter of the next); then compounds 2 and 3 (each within the scatter of the next).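

In this assay, within the data shown here, tert-butyl in place of ethyl on an aromatic carbon gives a number 14.1 percentage points lower from compound 2 to compound 4 (beyond the scatter) and is the first measured change of the alkyl group alone, showing that the read-out responds to this group at this place. With 3-(tert-butyl)phenyl in place of 4-methoxy-3-methylphenyl there is a number 6 percentage points higher from compound 1 to compound 4 (within the scatter), so the higher value of the 3-ethylphenyl compound 2 is not kept when its ethyl becomes tert-butyl. Nothing at hand accounts for the step.

Going by these compounds, whether methyl or isopropyl at this place would read like ethyl or like tert-butyl stays open, and so does the effect of an amine or a carboxylic acid there. With one concentration only, the values also leave open how the step would appear as a difference in potency.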